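The source may hold more compounds than are shown below. What is called first, only, known or untested is meant among the compounds shown, and "the series" means these compounds.

Working notes on the series. Compound 1 `Cc1cccc(-n2nncc2CN2C(=O)C3(C(C#N)=C(N)Oc4c3c3nc5ccccc5nc3c3ccccc43)c3ccccc32)c1` and compound 2 `Cc1cc(C)cc(-n2nncc2CN2C(=O)C3(C(C#N)=C(N)Oc4c3c3nc5ccccc5nc3c3ccccc43)c3ccccc32)c1` share the core and differ by a methyl in place of hydrogen on an aromatic carbon. In an ADME assay on L02 cells (Homo sapiens) for antiproliferative activity, read by MTT assay, with a stated time of 48 h (on this read-out lower numbers stand for stronger inhibition and higher numbers for weaker inhibition), compound 1 gives > 50000 nM, which is a limit of the assay and not a number. Compound 2 likewise gives > 50000 nM, again a limit. The step that the two limits leave unreadable from compound 1 to compound 2 is therefore not readable in size. Compound 3 `N#CC1=C(N)Oc2c(N)cc3nc4ccccc4nc3c2C12C(=O)N(Cc1cnnn1-c1cccc(Br)c1)c1ccccc12` carries an amino group on the core in place of the arene of the first two and gives > 50000 nM, once more a limit. Compound 3 thus stands at the limit, together with every other value shown, (the limit of > 50000 nM in this assay, at which 3 of the 3 values shown sit).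

Compound 4 `CCc1cccc(C)c1-n1nncc1CN1C(=O)C2(C(C#N)=C(N)Oc3c(N)cc4nc5ccccc5nc4c32)c2ccccc21` differs from compound 3 by 2-ethyl-6-methylphenyl in place of 3-bromophenyl on an aromatic nitrogen. For the measured compounds named here, the only measured step that bears on a change at the aryl group on the triazole is the one between compound 1 and compound 2, and that step is unreadable, so no direction or size can be taken from it; the three limits give no reading either. Compound 4 is therefore expected to sit at the limit as well, and the step that the limit leaves unreadable from compound 3 to compound 4 is expected to be not readable. The estimate for compound 4 is 80000 nM, with a range from 30000 nM to 300000 nM.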

Compound 4, half-maximal inhibitory concentration: > 50000 nM
Compound 4: no number, only a limit; the forecaster's own chance of this, stated with the estimate: 85%; the middle value is on the limit's open side.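

For the compounds shown here, the step between compound 3 and compound 4 cannot be read, and no new step arises; each compound stands at a limit, not a number, in this assay: the limit of > 50000 nM in this assay, at which 4 of the 4 values shown sit. The compounds shown leave open how far any of them lies from that limit, and whether changing the group on the aromatic nitrogen alters the read-out at all.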